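Swapping the aryl group on a growth inhibitor

This account rests on a few compounds, and the source may have more. Where it says the series, first, only, none or still open, it means among the compounds named here.

In a functional assay on NCI-H322M cells (Homo sapiens) for inhibition, read by sulforhodamine B assay, with a stated time of 48 h (a higher number here means a weaker inhibitor of growth, a lower number a stronger inhibitor of growth), compound 1 `O=C(Cc1csc2nc(-c3ccc(Br)cc3)cn12)N/N=C/c1ccccc1O` gives 10700 nM, and compound 2 `O=C(Cc1csc2nc(-c3ccc(Br)cc3)cn12)N/N=C/c1ccc(O)cc1` gives 34700 nM. That is the higher of the two numbers, which makes compound 2 the weaker growth inhibitor of this pair. Compound 3 `COc1cccc(OC)c1/C=N/NC(=O)Cc1csc2nc(-c3ccc(Br)cc3)cn12` has not yet been measured. Its structure differs from compound 2 as follows: 2,6-dimethoxyphenyl in place of 4-hydroxyphenyl on a carbon with a double bond to nitrogen. Going by the values given here, only one measured step bears on this change: a 3.2-fold higher number from compound 1 to compound 2 (0.51 log units; beyond the scatter), which came with 4-hydroxyphenyl in place of 2-hydroxyphenyl. The name 2,6-dimethoxyphenyl shares a number with the 2-hydroxyphenyl of compound 1 at 10700 nM, yet the group itself differs, so only a modest move toward a lower number in this assay is expected, possibly no larger than the usual scatter. The estimated change is a 1.8-fold lower number from compound 2 to compound 3 (0.26 log units; within the scatter). Compound 3 is expected at 19000 nM, within an estimated range of 7000 nM to 60000 nM.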

Compound 3, concentration for total growth inhibition: 61700 nM
For compound 3 the middle estimate is 3.2-fold (0.51 log units) below the measured one; measured number outside the range, above it.
By their numbers in this assay, from the lowest: compound 1; then compounds 2 and 3 (each within the scatter of the next).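

At the carbon with a double bond to nitrogen, 2,6-dimethoxyphenyl in place of 4-hydroxyphenyl gives a 1.8-fold higher number from compound 2 to compound 3 (0.25 log units; within the scatter) and so leaves these two groups indistinguishable in this assay. Set in place of 2-hydroxyphenyl, the same group gives a 5.8-fold higher number from compound 1 to compound 3 (0.76 log units; beyond the scatter) and so shows that a substituent numbered 2 on this ring does not by itself keep the lower number of the 2-hydroxyphenyl compound. No measurement shown here accounts for this difference.

The step from 2-hydroxyphenyl to 2,6-dimethoxyphenyl changes both the kind and the number of groups on the ring, so 2-methoxyphenyl or 2,6-dihydroxyphenyl would be needed to separate those two changes. As far as these compounds go, how this assay would read an amine or a carboxylic acid on the same ring also remains open.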